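This account rests on a few compounds, and the source may have more. Where it says the series, first, only, none or still open, it means among the compounds named here.

Within the data shown here, in an ADME assay on PC-3 cells (Homo sapiens) for cytotoxicity, read by sulforhodamine B assay, with a stated time of 48 h, tested at 10 uM (a higher number here means more inhibition at the concentration tested (going by the name of the read-out), a lower number less inhibition), compound 3 `CCCCCCCCc1cn(C(c2ccccc2)c2cc3cc(Br)ccc3nc2OC)nn1` gives 2.27%, the lowest of the three numbers so far, though its gap to compound 1 `CCCCCCCc1cn(C(c2ccccc2)c2cc3cc(Br)ccc3nc2OC)nn1`, which gives 4.42%, is within the scatter; compound 2 `COc1nc2ccc(Br)cc2cc1C(c1ccccc1)n1cc(CCCCCO)nn1` gives 12.9%. The step of a number 2.2 percentage points lower from compound 1 to compound 3 (within the scatter) lengthened the chain by a methyl, and the step of a number 10.6 percentage points lower from compound 2 to compound 3 (beyond the scatter) put propyl in place of hydroxy. Compound 4 `CCCCCc1cn(C(c2ccccc2)c2cc3cc(Br)ccc3nc2OC)nn1` shortens the chain of compound 3: hydrogen in place of propyl on a saturated chain carbon, five bonds along the chain from an aromatic carbon. Among the measured compounds shown here, only the step of a number 2.2 percentage points lower from compound 1 to compound 3 (within the scatter) concerns chain length alone, and it stayed within the scatter, so shortening the chain is expected to change this assay little, with a step of a number 2.7 percentage points higher from compound 3 to compound 4 (within the scatter) estimated. Compound 4 is therefore expected to give 5%, somewhere between -5% and 15%.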

Compound 4, a percentage reported as inhibition, at one concentration (the size of the read-out at that concentration, not a potency): 11.4%
Beside the measured number, compound 4's estimate is 6.4 percentage points below it; the range from low to high includes it.
By their numbers in this assay, from the lowest: compounds 3, 1, 4 and 2 (each within the scatter of the next, the first and the last beyond it).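

In this assay, shortening the chain gives a number 9.1 percentage points higher from compound 3 to compound 4 (within the scatter), and the same change at this position gives a number 7 percentage points higher from compound 1 to compound 4 (within the scatter), so chain length alone has not yet produced a step beyond the scatter. Hydrogen in place of hydroxy gives a number 1.5 percentage points lower from compound 2 to compound 4 (within the scatter), so the hydroxy-bearing chain cannot be told apart from the shorter plain chain, and the hydroxy need not be what separates compound 2 from compound 3. No measurement here explains these numbers. Still open, going by these compounds, is whether an amine, a carboxylic acid or a much longer chain at this position would give a step beyond the scatter.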